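A Hydroxyl Takes the Place of a Fluorine

The source may hold more compounds than are shown below. What is called first, only, known or untested is meant among the compounds shown, and "the series" means these compounds.

compound 1, `COc1ccc(C2=C(c3cc(OC)c(OC)c(OC)c3)C(=O)C(OC(C)=O)C2)cc1F`: < 1 ug/mL
compound 2, `COc1ccc(C2=C(c3cc(OC)c(OC)c(OC)c3)CC(O[SiH2]C(C)(C)C)C2=O)cc1[N+](=O)[O-]`: > 100 ug/mL

Of the compounds shown here, two have been tested in an ADME assay on L132 cells (Homo sapiens) for cytotoxicity, read by MTT assay, with a stated time of 72 h; a higher number here means a weaker inhibitor, a lower number a stronger inhibitor. Compound 1 gives < 1 ug/mL, which is a limit of the assay rather than a number (the limit of < 1 ug/mL in this assay, at which 1 of the 2 values shown sits). Compound 2 gives > 100 ug/mL, also a limit (the limit of > 100 ug/mL in this assay, at which 1 of the 2 values shown sits). Among the measured compounds shown here, the two share a core but differ in several places at once, so no single step can be read between them; their values show only that compound 1 sits at one end of the assay and compound 2 at the other.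

Compound 3, `COc1ccc(C2=C(c3cc(OC)c(OC)c(OC)c3)C(=O)C(OC(C)=O)C2)cc1O`, has not yet been measured. It differs from compound 1 in one place: hydroxy in place of fluoro on an aromatic carbon. Read one bond further out, the change is 3-fluoro-4-methoxyphenyl to 3-hydroxy-4-methoxyphenyl. Because compound 1 already sits at the limit of < 1 ug/mL in this assay, at which 1 of the 2 values shown sits, no gain can be seen, and the step that the limit leaves unreadable from compound 1 to compound 3 is expected to stay within the scatter. Compound 3 is therefore expected to give 0.5 ug/mL in this assay, between 0.1 ug/mL and 3 ug/mL.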

Compound 3, half-maximal inhibitory concentration: 6 ug/mL
For compound 3 the middle estimate is 12-fold (1.08 log units) below the measured one; the measured number lies above the stated range.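

In this assay, hydroxy in place of fluoro on this aromatic carbon, ortho to a methoxy group, gives an at least 6.0-fold higher number from compound 1 to compound 3 (0.77 log units; beyond the scatter) and so a weaker inhibitor. This position is therefore not indifferent to what sits on it: the exchange of one heavy atom for another is enough to move the value beyond the scatter, something the first two compounds, which differ in several places at once, could not show. The value of compound 1 is a limit and not a number: the limit of < 1 ug/mL in this assay, at which 1 of the 3 values shown sits.

The compounds shown leave open whether the loss of fluoro or the arrival of hydroxy matters more. They also leave open how a different group at this position, such as an amine or a chlorine atom, would read in this assay, on an otherwise unchanged core.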